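Dimethoxyphenyl for bromophenyl on a purine nucleoside core

This account rests on a few compounds, and the source may have more. Where it says the series, first, only, none or still open, it means among the compounds named here.

Measured compounds:
- compound 1, `OC[C@H]1O[C@@H](n2cnc3c(NCc4ccccc4Br)ncnc32)[C@H](O)[C@@H]1O`: 10000 nM
- compound 2, `OC[C@H]1O[C@@H](n2cnc3c(NCc4ccc(Cl)c(Cl)c4)ncnc32)[C@H](O)[C@@H]1O`: 10800 nM

Both compounds share a ribose-bearing purine core and differ only in the aryl group on a saturated chain carbon bound to a nitrogen on an aromatic ring. In a functional assay on K562 cells (Homo sapiens) for antiproliferative activity, with a stated time of 72 h (on this read-out lower numbers stand for stronger inhibition and higher numbers for weaker inhibition), compound 1 gives 10000 nM, and compound 2 gives 10800 nM. Going by the values given here, compound 1 stands at the lowest of the two numbers, with the step of a 1.1-fold higher number from compound 1 to compound 2 (0.03 log units; within the scatter) being the only measured comparison available.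

Compound 3, `COc1ccc(CNc2ncnc3c2ncn3[C@@H]2O[C@H](CO)[C@@H](O)[C@H]2O)c(OC)c1`, has not yet been measured. Its change from compound 1 is 2,4-dimethoxyphenyl in place of 2-bromophenyl on a saturated chain carbon bound to a nitrogen on an aromatic ring. Among the compounds with values here, the single step that bears on it, a 1.1-fold higher number from compound 1 to compound 2 (0.03 log units; within the scatter), exchanged one substituted phenyl for another at the same place and moved the number hardly at all. On that basis no step beyond the scatter is expected in this assay for compound 3, in either direction, since a different aryl substitution pattern left compound 2 where compound 1 was.

Compound 3 is therefore estimated at 10000 nM, within a range of 4000 nM to 25000 nM, which corresponds to an expected step of no change at the digits printed from compound 1 to compound 3 (within the scatter).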

Compound 3, half-maximal inhibitory concentration: > 166000 nM
Compound 3: only a limit was reported; the forecaster's own chance of this, stated with the estimate: 25%; at least 16-fold (1.22 log units) between middle value and limit.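

Compound 3 is reported only as a limit and not as a number: the limit of > 166000 nM in this assay, at which 1 of the 3 values shown sits. In this assay, the aryl group on a saturated chain carbon bound to a nitrogen on an aromatic ring turns out to matter: 2,4-dimethoxyphenyl in place of 2-bromophenyl gives an at least 16-fold higher number from compound 1 to compound 3 (1.22 log units; beyond the scatter), and 2,4-dimethoxyphenyl in place of 3,4-dichlorophenyl gives an at least 15-fold higher number from compound 2 to compound 3 (1.18 log units; beyond the scatter). Going by these compounds alone, the earlier pair, with a 1.1-fold higher number from compound 1 to compound 2 (0.03 log units; within the scatter), had compared only two halogen-bearing phenyl groups, whereas this change is the first to replace halogen with oxygen-bearing groups, bringing 2 hydrogen-bond acceptors where 2-bromophenyl has 0.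

The compounds shown leave open whether a single methoxy group on the phenyl ring would give a step of this size, or whether both methoxy groups are needed, and whether a hydroxyl group or an amine on that ring would track with the 2,4-dimethoxyphenyl compound or with the halogen-bearing ones. They also cannot tell how far compound 3 really lies past its limit, nor what lies behind the step, for which nothing measured here gives a cause.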